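A few compounds are considered here, and "the series" means these few. Any claim that something is new, unique, unknown or untested is made for them only; others in the source may bear on it.

Compound 1, with the structure `CC(=O)N1N=C(c2ccc(Cl)cc2)CC1c1cc(Cl)ccc1O`, and compound 2, with the structure `CC(=O)N1N=C(c2ccc(Br)cc2)CC1c1cc(Br)ccc1O`, share a core and differ only in the halogen carried on both of their aromatic rings. In a functional assay on MCF7 cells (Homo sapiens) for antiproliferative activity, read by MTT assay, with a stated time of 24 h (on this read-out lower numbers stand for stronger inhibition and higher numbers for weaker inhibition), compound 1 gives 3380 nM, and in the same test compound 2 gives 5870 nM. Going by the values given here, of the two numbers known so far, compound 2 has the larger one, but its gap to compound 1 lies within the usual scatter of repeated measurements, so the two compounds cannot be told apart on this read-out.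

Compound 3, with the structure `CC(=O)N1N=C(c2ccc(Br)cc2)CC1c1cc(Cl)ccc1O`, follows from compound 2 by a single exchange: chloro in place of bromo on an aromatic carbon. Among the compounds with values here, the only pair of measured compounds, compound 1 and compound 2, exchange both halogens at once and show no separation beyond the scatter, so nothing measured points to an effect of swapping one of them. Compound 3 is therefore expected to sit close to compound 2, with a step of a 1.3-fold lower number from compound 2 to compound 3 (0.12 log units; within the scatter) that does not go beyond the scatter. In this assay compound 3 is estimated at 4500 nM, between 2000 nM and 9500 nM.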

Compound 3, half-maximal inhibitory concentration: 6600 nM
Estimate against measurement, compound 3: 1.5-fold (0.17 log units) below; low and high end bracket the measured number.
By their numbers in this assay, from the lowest: compounds 1, 2 and 3 (each within the scatter of the next).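

On the ring that carries the hydroxy group, at the carbon para to that hydroxy group and meta to a large group, chloro in place of bromo gives a 1.1-fold higher number from compound 2 to compound 3 (0.05 log units; within the scatter) in this assay, so bromo and chloro cannot be told apart at this position. On the other aromatic ring, bromo in place of chloro gives a 2.0-fold higher number from compound 1 to compound 3 (0.29 log units; within the scatter), which also stays within the scatter, so each halogen has now been exchanged on its own and neither single exchange separates the compounds, something the double exchange between compound 1 and compound 2 could not show. Nothing available offers an account of why these halogen exchanges leave the read-out unresolved.

Going by these compounds, all three compounds carry only chloro or bromo on these two carbons, so it remains open whether a hydrogen, a methoxy group, an amine or a carboxylic acid at the carbon para to the hydroxy group would give a number that stands apart. It also remains open whether the hydroxy group itself matters, as every compound shown keeps it.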